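The source may hold more compounds than are shown below. What is called first, only, known or untested is meant among the compounds shown, and "the series" means these compounds.

Of the compounds shown here, two have so far been measured in an assay for inhibition of Fatty-acid amide hydrolase 1 (Rattus norvegicus); a higher number here means a weaker inhibitor, a lower number a stronger inhibitor. Compound 1 `COC(=O)c1ccc(C#CCCCCC(=O)c2ncc(-c3ccccn3)o2)cc1` gives 25 nM. Compound 2 `COC(=O)c1ccccc1CCCCCCC(=O)c1ncc(-c2ccccn2)o1` gives 1 nM, the lower of the two numbers, and the gap between compound 2 and compound 1 lies beyond the scatter of repeated measurements. Compound 3 `O=C(CCCCCCc1ccccc1C(=O)O)c1ncc(-c2ccccn2)o1` has not yet been measured. It differs from compound 2 in one place: hydrogen in place of methyl on an oxygen next to a carbonyl group, a hydrogen in place of methyl on an oxygen next to a carbonyl group, so that a methoxycarbonyl becomes a carboxy group. Within the data shown here, no measured pair of compounds shows this change, so its effect in this assay is unknown. A modest step toward a higher number seems the most plausible expectation, and the estimated step from compound 2 is a 3.0-fold higher number from compound 2 to compound 3 (0.48 log units; beyond the scatter). Compound 3 is therefore expected to give 3 nM, with a range from 0.5 nM to 20 nM.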

Compound 3, inhibition constant: > 600 nM
Compound 3 was reported as a limit; the forecaster's own chance of this, stated with the estimate: 2%; at least 200-fold (2.30 log units) between middle value and limit.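

The change from methyl to hydrogen on this oxygen, which turns the methoxycarbonyl into a carboxy group, has a large effect in this assay: it gives an at least 600-fold higher number from compound 2 to compound 3 (2.77 log units; beyond the scatter). Compound 3 is reported only as a limit, > 600 nM. This single small change at this position therefore separates a very strong inhibitor from a far weaker one, and the step has no measured upper end: the limit of > 600 nM in this assay, at which 1 of the 3 values shown sits.

This one pair cannot show whether the same change would cost as much in compound 1, whose methoxycarbonyl sits on a different chain. On these data alone, how an ethyl ester or a primary amide would read in place of the methoxycarbonyl, and so whether the carboxy group is a special case, also remains open.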